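Ethyl in Place of Nitro: Expected Cytotoxicity of Compound 4

The source may report more compounds than this note shows. Statements on the series, on what has been measured and on what is new or still open speak of the compounds shown alone.

compound 1 `Fc1ccc(-c2noc(Cc3c[nH]c4ccccc34)n2)cc1` gives 13600 nM
compound 2 `Clc1ccc(-c2noc(Cc3c[nH]c4ccccc34)n2)cc1` gives 42800 nM
compound 3 `O=[N+]([O-])c1ccc(-c2noc(Cc3c[nH]c4ccccc34)n2)cc1` gives the limit > 50000 nM

All three were tested in an ADME assay on cells (Splenocyte, Mus musculus, strain BALB/c) for cytotoxicity, read by CCK-8 assay, with a stated time of 48 h; on this read-out lower numbers stand for higher toxicity in this test and higher numbers for lower toxicity in this test. For compound 3 the result is a limit rather than a number, and it sits at the limit of > 50000 nM in this assay, at which 1 of the 3 values shown sits, the only one of the three to do so. Compound 4 `CCc1ccc(-c2noc(Cc3c[nH]c4ccccc34)n2)cc1` has not been measured; it differs from compound 3 as ethyl in place of nitro on an aromatic carbon. Within the data shown here, no measured step swaps nitro for ethyl. The steps seen are a 3.1-fold higher number from compound 1 to compound 2 (0.50 log units; beyond the scatter) and an at least 3.6-fold higher number from compound 1 to compound 3 (0.56 log units; beyond the scatter), while an at least 1.1-fold higher number from compound 2 to compound 3 (0.06 log units; that floor lies within the scatter). These give little guidance, so a step back toward the numbers of compound 1 and compound 2 is expected, as an at least 1.7-fold lower number from compound 3 to compound 4 (0.25 log units; that floor lies within the scatter). Compound 4 is therefore estimated at 28000 nM, within 8000 nM to 60000 nM.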

Compound 4, half-maximal cytotoxic concentration: 24400 nM
Compound 4: middle estimate off by 1.1-fold (0.06 log units), on the high side; low and high end bracket the measured number.
By their numbers in this assay, from the lowest: compounds 1, 4 and 2 (each within the scatter of the next, the first and the last beyond it). At a limit, above all of these: compound 3.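

Putting ethyl in place of nitro at this position gives an at least 2.0-fold lower number from compound 3 to compound 4 (0.31 log units; beyond the scatter), so in this assay a plain carbon chain does not stay with the nitro compound. Against the halogens, ethyl gives a 1.8-fold higher number from compound 1 to compound 4 (0.25 log units; within the scatter) and a 1.8-fold lower number from compound 2 to compound 4 (0.24 log units; within the scatter), so it cannot be told apart from either fluoro or chloro here. The nitro step is only a floor, because compound 3 gives a limit rather than a number: the limit of > 50000 nM in this assay, at which 1 of the 4 values shown sits.

On these data alone, how an amine, a carboxylic acid or a longer chain would read at this position stays open. As far as these compounds go, the true value of compound 3 also stays unknown.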